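From compound 3 to compound 4 on the carbonyl carbon

This account rests on a few compounds, and the source may have more. Where it says the series, first, only, none or still open, it means among the compounds named here.

In an ADME assay on cells (Hepatocyte, Rattus norvegicus, strain Wistar) for pharmacokinetics, read by LC-MS, with a stated time of 90 min, tested at 1 uM (on this read-out higher numbers stand for fast clearance and lower numbers for slow clearance), compound 1 `CCCN(CC1CCOC1)C(=O)c1cc(OC)c2oc(NCc3cccc(Cl)c3)nc2c1` gives 65 mL/min/kg, compound 2 `COc1cc(C(=O)N2CCCC2(C)C)cc2nc(NCc3cccc(Cl)c3)oc12` gives 58.3 mL/min/kg and compound 3 `COc1cc(C(=O)N2CC[C@H](O)[C@@H](C)C2)cc2nc(NCc3cccc(Cl)c3)oc12` gives 36.7 mL/min/kg. These three values lie within the scatter of one another, so compound 3 stands clearly apart from neither of the others. Compound 4 `COc1cc(C(=O)N2CC(C)C(O)CC2C)cc2nc(NCc3cccc(Cl)c3)oc12` carries 4-hydroxy-2,5-dimethylpiperidin-1-yl in place of 4-hydroxy-3-methylpiperidin-1-yl on a carbonyl carbon. Among the compounds with values here, the steps that bear on this change, all made at that same carbonyl carbon, are a 1.6-fold lower number from compound 2 to compound 3 (0.20 log units; within the scatter), a 1.8-fold lower number from compound 1 to compound 3 (0.25 log units; within the scatter) and a 1.1-fold lower number from compound 1 to compound 2 (0.05 log units; within the scatter). On that evidence, no step beyond the scatter is expected in this assay, and the estimated step is a 1.1-fold higher number from compound 3 to compound 4 (0.04 log units; within the scatter). The estimate for compound 4 is an expected 40 mL/min/kg, with a range of 24 mL/min/kg to 62 mL/min/kg.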

Compound 4, clearance: 56.7 mL/min/kg
For compound 4 the middle estimate is 1.4-fold (0.15 log units) below the measured one; low and high end bracket the measured number.
By their numbers in this assay, from the lowest: compounds 3, 4, 2 and 1 (each within the scatter of the next).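

In this assay, the second methyl on the piperidine ring gives a 1.5-fold higher number from compound 3 to compound 4 (0.19 log units; within the scatter), so this change at the carbonyl carbon stays inside the scatter. The new group stands clearly apart from neither of the other amides, with a 1.0-fold lower number from compound 2 to compound 4 (0.01 log units; within the scatter) and a 1.1-fold lower number from compound 1 to compound 4 (0.06 log units; within the scatter), and no data at hand explain these small steps. Open, as far as these compounds go, is whether defined stereocentres in 4-hydroxy-2,5-dimethylpiperidin-1-yl would alter clearance, and whether a morpholine or a piperazine on the carbonyl carbon would give a step beyond the scatter.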